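From thiophen-2-yl to 4-chlorophenyl on the carbonyl carbon

A few compounds are considered here, and "the series" means these few. Any claim that something is new, unique, unknown or untested is made for them only; others in the source may bear on it.

Compound 1 `O=C(C=CNc1cc(-c2ccccc2)nn1-c1ccccc1)c1ccc(Br)cc1`: 8810 nM
Compound 2 `O=C(C=CNc1cc(-c2ccccc2)nn1-c1ccccc1)c1cccs1`: 2420 nM

Within the data shown here, in a functional assay on HepG2 cells (Homo sapiens) for inhibition, read by MTT assay, with a stated time of 48 h (a higher number here means a weaker inhibitor, a lower number a stronger inhibitor), compound 2 holds the lower of the two numbers so far, which makes it the stronger inhibitor of the pair. The next compound, compound 3 `O=C(C=CNc1cc(-c2ccccc2)nn1-c1ccccc1)c1ccc(Cl)cc1`, has not yet been measured. It differs from compound 2 as follows: 4-chlorophenyl in place of thiophen-2-yl on a carbonyl carbon. In words, 4-chlorophenyl stands in place of thiophen-2-yl on a carbonyl carbon. Among the measured compounds shown here, one measured step bears on this: a 3.6-fold lower number from compound 1 to compound 2 (0.56 log units; beyond the scatter). That step is modest but beyond the scatter, and the change in compound 3 runs the opposite way, away from thiophen-2-yl. The data hold no direct comparison of 4-chlorophenyl with 4-bromophenyl. A step of similar size toward a higher number is therefore expected in this assay. The estimated step is a 3.1-fold higher number from compound 2 to compound 3 (0.49 log units; beyond the scatter). Compound 3 is expected at 7500 nM, with an estimated range of 3200 nM to 17000 nM.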

Compound 3, half-maximal inhibitory concentration: 41200 nM
For compound 3 the middle estimate is 5.5-fold (0.74 log units) below the measured one, outside the stated range (above it).
By their numbers in this assay, from the lowest: compound 2; then compound 1; then compound 3.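

In this assay the group on the carbonyl carbon matters more than the first pair showed, with a 17-fold higher number from compound 2 to compound 3 (1.23 log units; beyond the scatter) as a large step where the earlier one was modest. The halogen also counts, since chloro in place of bromo gives a 4.7-fold higher number from compound 1 to compound 3 (0.67 log units; beyond the scatter) as a modest step, so the two halogen-bearing phenyl compounds do not stand as equivalents here. Nothing available accounts for either step.

The compounds shown leave open how an unsubstituted phenyl, a 4-fluorophenyl or a 4-methoxyphenyl would fall on this carbonyl carbon, and so whether the order of bromo and chloro extends to other substituents. They also leave open whether another five-membered aromatic ring, such as furan-2-yl, would keep the lower number of compound 2.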